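The source may report more compounds than this note shows. Statements on the series, on what has been measured and on what is new or still open speak of the compounds shown alone.

Working notes on the series.

Three compounds in this series have a number in a physicochemical assay for lipophilicity, read by HPLC, at pH 7.5; a lower number here means a more polar compound, a higher number a more lipophilic compound. Compound 1 `CCOc1ccccc1-c1ccc(-c2nc3cnccc3c(N[C@@H]3CCOC3=O)c2C#N)cc1` gives 2.7 in this assay. Compound 2 `CC[C@@H](Nc1c(C#N)c(-c2ccc(-c3ccccc3NC)cc2)nc2cnccc12)C(N)=O` gives 2.5 in this assay. Compound 3 `CC[C@@H](Nc1c(C#N)c(-c2ccc(Br)cc2)nc2cnccc12)C(=O)O` gives 1.6 in this assay. Among these three numbers compound 2 stands second highest; its nearest neighbour is compound 1, whose number lies within the scatter of that of compound 2, so no order between the two can be read from them; its furthest neighbour is compound 3, whose number lies beyond the scatter and clearly lower.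

Compound 4 `CC[C@@H](Nc1c(C#N)c(-c2ccc(-c3cccc(CO)c3)cc2)nc2cnccc12)C(N)=O` has not yet been measured in this assay. It differs from compound 2 in one place: 3-(hydroxymethyl)phenyl in place of 2-(methylamino)phenyl on an aromatic carbon. Among the measured compounds shown here, no pair of measured compounds differs in this way, so no measured step shows what this change does here. The numbers of compound 1 and compound 2, which carry different groups at the same kind of position, sit within the scatter of each other. On that basis the step from compound 2 to compound 4 is expected to be small, most likely downward, and quite possibly not beyond the scatter; the expected step is a number 0.30 log units lower from compound 2 to compound 4 (within the scatter). Compound 4 is therefore estimated at 2.2 in this assay, with a range from 1.7 to 2.7.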

Compound 4, distribution coefficient: 2
Estimate against measurement, compound 4: 0.20 log units above; the range from low to high includes it.
By their numbers in this assay, from the lowest: compound 3; then compound 4; then compounds 2 and 1 (each within the scatter of the next).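

In this assay, among the compounds shown here, 3-(hydroxymethyl)phenyl in place of 2-(methylamino)phenyl on an aromatic carbon gives a number 0.50 log units lower from compound 2 to compound 4 (beyond the scatter), the first step that can be read at this position. For the compounds shown here, the position is therefore not silent in this assay: a change here can move the number past the scatter, which the earlier compounds, differing in more than one place, could not show. This happens even though the two groups have the same counts of heavy atoms, hydrogen-bond donors and hydrogen-bond acceptors, and neither carries a net charge, while no measurement at hand gives a reason for the step.

The compounds shown leave open how much of the step belongs to the group itself and how much to where it stands on the phenyl ring; a 2-(hydroxymethyl)phenyl or a 3-(methylamino)phenyl group would separate the two. Also open, going by these compounds, is where an amine such as 3-(aminomethyl)phenyl or a carboxylic acid such as 3-carboxyphenyl would fall at this position.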